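The compounds below may be only part of what the source reports. "The series", "measured", "known", "first", "only" and "open" are said of these compounds alone.

Of the compounds shown here, two have been measured in a functional assay on MGC-803 cells (Homo sapiens) for cytotoxicity, read by MTT assay, with a stated time of 38 h; on this read-out higher numbers stand for weaker inhibition and lower numbers for stronger inhibition. Compound 1 (`COc1cc(OC)c2c(=O)c(OCC(=O)N/N=C/c3sccc3C)c(-c3cc(OC)c(OC)c(OC)c3)oc2c1`) gives 7740 nM, and compound 2 (`COc1cc(OC)c2c(=O)c(OCCCCN3CCCC3)c(-c3cc(OC)c(OC)c(OC)c3)oc2c1`) gives 18600 nM. Compound 2 therefore holds the higher of the two numbers, which makes it the weaker of the two on this read-out.

The next compound to be measured is compound 3 (`COc1cc(OC)c2c(=O)c(OCC(=O)N/N=C/c3ccc(C)cc3)c(-c3cc(OC)c(OC)c(OC)c3)oc2c1`). Its difference from compound 2 is a group of 12 heavy atoms (9 carbon, 2 nitrogen, 1 oxygen; one six-membered aromatic ring of carbon only) in place of a group of 8 heavy atoms (7 carbon, 1 nitrogen; one five-membered non-aromatic ring with 1 hetero atom), on a saturated chain carbon bound to an oxygen on an aromatic ring. The 3-(pyrrolidin-1-yl)propyl leaves, and a group with a six-membered aromatic ring of carbon only enters.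

Going by the values given here, only one measured step bears on this change: a 2.4-fold higher number from compound 1 to compound 2 (0.38 log units; beyond the scatter), which is modest but beyond the scatter. Read in reverse, that step also replaces the 3-(pyrrolidin-1-yl)propyl with a larger group containing an aromatic ring, and it lowers the number. Among the compounds with values here, it is a single step, and the data hold no measured example of the six-membered ring. A step of similar modest size, toward a lower number, is therefore expected in this assay, estimated as a 2.3-fold lower number from compound 2 to compound 3 (0.37 log units; beyond the scatter). For compound 3 the estimated value is 8000 nM, with an expected range of 3000 nM to 20000 nM.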

Compound 3, half-maximal inhibitory concentration: 3510 nM
Compound 3: middle estimate off by 2.3-fold (0.36 log units), on the high side; low and high end bracket the measured number.
By their numbers in this assay, from the lowest: compound 3; then compound 1; then compound 2.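

In this assay, the change on a saturated chain carbon bound to an oxygen on an aromatic ring now has a second example: the group with the six-membered aromatic ring of carbon only gives a 5.3-fold lower number from compound 2 to compound 3 (0.72 log units; beyond the scatter) and so extends the direction seen with compound 1, as both compounds carrying an aromatic ring in this group stand lower than compound 2, and none of the three goes against this. The aromatic ring also counts on its own, as 4-methylphenyl in place of 3-methylthiophen-2-yl on a carbon with a double bond to nitrogen gives a 2.2-fold lower number from compound 1 to compound 3 (0.34 log units; beyond the scatter) and leaves compound 3 lowest of the three, with its steps to both others beyond the scatter. No measured evidence accounts for either step.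

The compounds shown leave open what the methyl on the ring contributes, and whether an unsubstituted phenyl, a pyridine ring or a carboxylic acid on the ring would move the number further. In the step from the 3-(pyrrolidin-1-yl)propyl the whole group changes at once, so the shares of the aromatic ring, the carbonyl and the double bond to nitrogen stay unseparated, and a piperidine or a longer chain remains an open comparison.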